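Sulfonyl substituent on the hydroxyphenyl biphenyl sulfonamide

The compounds below may be only part of what the source reports. "The series", "measured", "known", "first", "only" and "open" are said of these compounds alone.

Compound 3 `CS(=O)(=O)Nc1ccc(-c2ccc(O)cc2)cc1` in an assay for binding affinity to 17-beta-hydroxysteroid dehydrogenase type 2 (Homo sapiens), with a stated time of 20 min, tested at 1 uM (a higher number here means more inhibition at the concentration tested (going by the name of the read-out), a lower number less inhibition), gives < 10%, which is a limit of the assay and not a number. Compound 1 `CS(=O)(=O)Nc1ccc(-c2ccc(CO)cc2)cc1` in this assay likewise gives < 10%, again a limit. Compound 2 `Cc1cccc(S(=O)(=O)Nc2ccc(-c3ccc(CO)cc3)cc2)c1` gives 12%. The step of a number at least 2 percentage points higher from compound 1 to compound 2 (that floor lies within the scatter) is the same change now applied to compound 3: 3-methylphenyl in place of methyl on a sulfonyl sulfur. Compound 4 `Cc1cccc(S(=O)(=O)Nc2ccc(-c3ccc(O)cc3)cc2)c1` is the result. Since that measured step stayed within the scatter, and since compound 3 sits at the limit of < 10% in this assay, at which 2 of the 3 values shown sit, no step beyond the scatter is expected in this assay; the step of a number at least 1 percentage points higher from compound 3 to compound 4 (that floor lies within the scatter) is estimated as small, with a fair chance that compound 4 is again reported only as a limit. Compound 4 is therefore expected near 11%, within 2% to 24%.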

Compound 4, a percentage reported as inhibition, at one concentration (the size of the read-out at that concentration, not a potency): 14%
The estimate for compound 4 lay 3 percentage points below the measured number, within the range that was stated.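

In this assay, within the data shown here, the step on the core of compound 3 is a number at least 4 percentage points higher from compound 3 to compound 4 (that floor lies within the scatter), so methyl to 3-methylphenyl on a sulfonyl sulfur has now been seen on two cores: the same change on two cores in this assay, a number at least 2 percentage points higher (that floor lies within the scatter) from compound 1 to compound 2 and a number at least 4 percentage points higher (that floor lies within the scatter) from compound 3 to compound 4; the limit leaves it open whether they differ With 3-methylphenyl in place, hydroxy in place of hydroxymethyl on an aromatic carbon becomes readable for the first time, giving a number 2 percentage points higher from compound 2 to compound 4 (within the scatter).

As far as these compounds go, the true size of either step from methyl remains open. Also open, from the compounds shown here alone, is whether a carboxylic acid on the aromatic ring or a longer chain on the sulfonyl sulfur would give a step beyond the scatter.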